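Removing one hydroxy from the caffeoyl ester of compound 2

The source may hold more compounds than are shown below. What is called first, only, known or untested is meant among the compounds shown, and "the series" means these compounds.

Measured so far:
compound 1 `COC(=O)[C@]1(O)C[C@@H](O)[C@@H](OC(=O)/C=C/c2ccc(O)c(O)c2)[C@H](OC(=O)/C=C/c2ccc(O)c(O)c2)C1`: 24600 nM
compound 2 `COC(=O)[C@]1(O)C[C@@H](O)[C@@H](O)[C@H](OC(=O)/C=C/c2ccc(O)c(O)c2)C1`: 12100 nM

In a functional assay on BV-2 cells (Mus musculus) for inhibition, read by Griess assay, with a stated time of 10 min (a higher number here means a weaker inhibitor, a lower number a stronger inhibitor), compound 1 gives 24600 nM and compound 2 gives 12100 nM. Among the compounds with values here, the only measured step, a 2.0-fold lower number from compound 1 to compound 2 (0.31 log units; beyond the scatter), removes a whole ester group from the shared core, and compound 2 thereby holds the lowest of the two numbers. Compound 3 `COC(=O)[C@]1(O)C[C@@H](O)[C@@H](O)[C@H](OC(=O)/C=C/c2ccc(O)cc2)C1` is the next member, and it differs from compound 2 by hydrogen in place of hydroxy on an aromatic carbon. Within the data shown here, no measured step touches the aromatic ring of the ester, so the single step at hand bears only indirectly on this change. He therefore expects that losing one of the two hydroxy groups weakens the inhibition modestly, a step of a 2.1-fold higher number from compound 2 to compound 3 (0.32 log units; beyond the scatter) in this assay. For compound 3 he estimates 25000 nM, within 10000 nM to 60000 nM.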

Compound 3, half-maximal inhibitory concentration: 82000 nM
Compound 3: the middle estimate sits 3.3-fold (0.52 log units) below what was measured; the measured number lies above the stated range.
By their numbers in this assay, from the lowest: compound 2; then compound 1; then compound 3.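

In this assay the change from 3,4-dihydroxyphenyl to 4-hydroxyphenyl gives a 6.8-fold higher number from compound 2 to compound 3 (0.83 log units; beyond the scatter) and so shows that the aromatic ring of the ester is sensitive to this one hydroxy group. This step is larger than a 2.0-fold lower number from compound 1 to compound 2 (0.31 log units; beyond the scatter) for the loss of a whole ester group, so in this short series a single aromatic hydroxy counts for more than the second ester. Nothing available explains the size of this step.

The compounds shown leave open whether a methoxy group or a fluorine atom in place of the lost hydroxy would restore the number of compound 2, and how much the remaining hydroxy contributes. They also leave open whether the same change would have a similar effect on the two esters of compound 1.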